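Exchanging the indole amide for a dienamide on the octadecyl series

A few compounds are considered here, and "the series" means these few. Any claim that something is new, unique, unknown or untested is made for them only; others in the source may bear on it.

Measured compounds in a functional assay on SiHa cells (Homo sapiens) for cytotoxicity, read by MTT assay, with a stated time of 48 h; on this read-out lower numbers stand for stronger inhibition and higher numbers for weaker inhibition:
- compound 1, `C/C=C/C=C/C(=O)N[C@H](C(=O)NCCCCCCCCCCCC)[C@@H](C)O`: > 200000 nM, a limit of the assay and not a number
- compound 2, `CCCCCCCCCCCCCCCCCCNC(=O)[C@@H](NC(=O)c1nccc2ccccc12)[C@@H](C)O`: 51200 nM
- compound 3, `CCCCCCCCCCCCCCCCCCNC(=O)[C@@H](NC(=O)c1cc2ccccc2n1C)[C@@H](C)O`: 113000 nM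

Compound 3 gives the highest of the two numbers in this assay; its nearest neighbour is compound 2, and the step of a 2.2-fold higher number from compound 2 to compound 3 (0.34 log units; beyond the scatter) is a modest one. Compound 1 shows only a limit, (the limit of > 200000 nM in this assay, at which 1 of the 3 values shown sits).

Compound 4 is `C/C=C/C=C/C(=O)N[C@H](C(=O)NCCCCCCCCCCCCCCCCCC)[C@@H](C)O`. It differs from compound 3 as follows: penta-1,3-dien-1-yl in place of 1-methyl-1H-indol-2-yl on a carbonyl carbon. Going by the values given here, none of the measured steps covers this exchange; the only measured step, a 2.2-fold higher number from compound 2 to compound 3 (0.34 log units; beyond the scatter), swaps one aromatic amide for another, while here an aromatic group gives way to an open chain. Compound 1, which carries the same penta-1,3-dien-1-yl group on a shorter chain, sits at the limit, so a weak result is expected. The step of a 1.4-fold higher number from compound 3 to compound 4 (0.15 log units; within the scatter) is therefore estimated to go toward higher numbers, with a fair chance that only a limit is reported. Compound 4 is expected to give about 160000 nM in this assay, within 50000 nM to 400000 nM.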

Compound 4, half-maximal inhibitory concentration: > 200000 nM
Compound 4 gave a limit, no number; the forecaster's own chance of this, stated with the estimate: 50%; middle value at least 1.2-fold (0.09 log units) away from the limit.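

In this assay compound 4 gives > 200000 nM, which is a limit of the assay and not a number. At this place on the carbonyl carbon, the exchange of the aromatic groups for penta-1,3-dien-1-yl gives an at least 1.7-fold higher number from compound 3 to compound 4 (0.24 log units; that floor lies within the scatter) and an at least 3.9-fold higher number from compound 2 to compound 4 (0.59 log units; beyond the scatter), so the open chain is separated beyond the scatter only from isoquinolin-1-yl, while its floor against 1-methyl-1H-indol-2-yl lies within the scatter. The step from compound 1 to compound 4 cannot be read, so the added hexyl shows no effect that can be stated, and both dienamides end at the same limit: the limit of > 200000 nM in this assay, at which 2 of the 4 values shown sit.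

From the compounds shown here alone, whether a saturated pentyl group or a simple phenyl group on this carbonyl carbon would give a number remains open. Also open, going by these compounds, is how the isoquinolin-1-yl amide would respond to a chain shorter than octadecyl.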